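Bromo for Trifluoromethyl, Carried to a Second Place

The source may report more compounds than this note shows. Statements on the series, on what has been measured and on what is new or still open speak of the compounds shown alone.

Three measured compounds share a core and differ in the group on the pendant aromatic ring. Compound 1 `O=C1/C(=C/c2ccccc2C(F)(F)F)CCc2c(O)cccc21` carries a trifluoromethyl group; in a functional assay on RAW264.7 cells (Mus musculus) for inhibition (on this read-out lower numbers stand for stronger inhibition and higher numbers for weaker inhibition), compound 1 gives 3830 nM. Compound 3 `O=C1/C(=C/c2ccccc2Br)CCc2c(O)cccc21` carries bromo instead, the change being (bromo in place of trifluoromethyl on an aromatic carbon), and in this assay compound 3 gives 1240 nM. That change made a 3.1-fold lower number from compound 1 to compound 3 (0.49 log units; beyond the scatter). Compound 2 `O=C1/C(=C/c2cccc(C(F)(F)F)c2)CCc2c(O)cccc21` has the same atoms as compound 1 joined differently; the difference between the two cores is not broken down here. In this assay compound 2 gives 1970 nM. Compound 4 `O=C1/C(=C/c2cccc(Br)c2)CCc2c(O)cccc21`, not yet measured, arises from compound 2 through (bromo in place of trifluoromethyl on an aromatic carbon). This is the same kind of change as that from compound 1 to compound 3, but the place is not the same: there it was ortho to a large group, here it is meta to a large group. Resting on a 3.1-fold lower number from compound 1 to compound 3 (0.49 log units; beyond the scatter), and with the place not the same, the expected step in this assay is a 2.0-fold lower number from compound 2 to compound 4 (0.29 log units; within the scatter). Compound 4 is thus estimated at 1000 nM, with a range from 500 nM to 2500 nM.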

Compound 4, half-maximal inhibitory concentration: 1700 nM
Compound 4: the middle estimate sits 1.7-fold (0.23 log units) below what was measured, and the stated range covers the measured number.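

In this assay, among these compounds, bromo in place of trifluoromethyl gives a 1.2-fold lower number from compound 2 to compound 4 (0.06 log units; within the scatter), so at this place, meta to a large group, the change produces no step that can be told from the scatter. The change therefore does not carry from one compound pair to the other at the same size, and the gap between the two steps is itself beyond the scatter: the same change on two cores in this assay, a 3.1-fold lower number (0.49 log units; beyond the scatter) from compound 1 to compound 3 and a 1.2-fold lower number (0.06 log units; within the scatter) from compound 2 to compound 4, 2.7-fold (0.43 log units) apart, beyond the scatter of two such steps

This shows that the step seen for the first pair cannot simply be transferred within this series, but two pairs do not show what sets the steps apart, nor how the same change would behave on any further core.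

The compounds shown leave open how chloro, methoxy, an amine or a carboxylic acid on the pendant aromatic ring would read in this assay. They also leave open whether bromo and trifluoromethyl would again part ways if the hydroxyl on the shared core gave way to a methoxy group.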